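Shortening the alkyne side chain of a cytidine analogue

This account rests on a few compounds, and the source may have more. Where it says the series, first, only, none or still open, it means among the compounds named here.

Compound 1 `CCC#C[C@@]1(O)[C@@H](CO)O[C@@H](n2ccc(N)nc2=O)[C@@H]1O`: 129000 nM
Compound 2 `C#C[C@@]1(O)[C@H](O)[C@@H](CO)O[C@H]1n1ccc(N)nc1=O`: > 350000 nM
Compound 3 `C#C[C@]1(O)[C@H](O)[C@@H](CO)O[C@H]1n1ccc(N)nc1=O`: > 350000 nM

Of the compounds shown here, three have been measured in a functional assay on L1210 cells (Mus musculus), read by MTT assay; a lower number here means a stronger inhibitor, a higher number a weaker inhibitor. Among the measured compounds shown here, compound 1 gives 129000 nM, the only number in the set. Compound 2 gives only a limit of the assay, > 350000 nM. Compound 3 likewise gives only a limit, > 350000 nM. The step that the two limits leave unreadable from compound 2 to compound 3 therefore cannot be read, because the limit of > 350000 nM in this assay, at which 2 of the 3 values shown sit, and because of the fact that compounds 2 and 3 differ only in the configuration as drawn.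

The unmeasured compound 4 `CC#C[C@@]1(O)[C@@H](CO)O[C@@H](n2ccc(N)nc2=O)[C@@H]1O` differs from compound 1 by hydrogen in place of methyl on a saturated chain carbon bound to a triple-bonded carbon. For the measured compounds named here, no measured step bears directly on this change; the only measured compounds carrying the shortest alkyne, compound 2 and compound 3, show only limits, and their alkyne sits at a different ring position. Since compound 1 alone gives a number, a modest weakening toward the limit is expected, and compound 4 is estimated at 220000 nM, with a range from 80000 nM to 400000 nM, meaning an expected step of a 1.7-fold higher number from compound 1 to compound 4 (0.23 log units; within the scatter).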

Compound 4, half-maximal inhibitory concentration: 24500 nM
For compound 4 the middle estimate is 9.0-fold (0.95 log units) above the measured one, and the stated range ends above it.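

In this assay, among the compounds shown here, this pair gives the first readable step in the set: going from but-1-yn-1-yl to prop-1-yn-1-yl produces a 5.3-fold lower number from compound 1 to compound 4 (0.72 log units; beyond the scatter), so this small change on the alkyne chain moves the number towards a stronger inhibitor. For the compounds shown here, the earlier compounds could not show this, as compound 1 was the only one with a number, while compound 2 and compound 3 gave only limits and the step between them cannot be read. Nothing shown here accounts for the direction of the step.

From the compounds shown here alone, it remains open whether a longer chain such as pent-1-yn-1-yl would continue this direction on the core of compound 1, as a single step sets no trend. Also open, going by these compounds, is how an amine at the end of the chain would fare in this position.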